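From ethoxycarbonyl to carboxy on a shared core

The compounds below may be only part of what the source reports. "The series", "measured", "known", "first", "only" and "open" are said of these compounds alone.

Measured so far in a functional assay on the whole organism (blood) with Rattus norvegicus as the target; on this read-out lower numbers stand for an effect already at smaller amounts and higher numbers for an effect only at larger amounts of compound (lower numbers mean an effect at smaller amounts)
Compound 1 `CCOC(=O)C1(CCCc2ccc(Cl)cc2)CO1` gives 200 umol/kg
Compound 2 `CCOC(=O)C1(CCCCCc2ccc(Cl)cc2)CO1` gives 20 umol/kg

Of these two, compound 1 carries the higher number, and its gap to compound 2 lies beyond the usual scatter. The next compound to be tested in this assay is compound 3 `O=C(O)C1(CCCc2ccc(Cl)cc2)CO1`, which differs from compound 1 by one change (hydrogen in place of ethyl on an oxygen next to a carbonyl group). Hydrogen stands in place of ethyl on an oxygen next to a carbonyl group, so ethoxycarbonyl becomes carboxy. Going by the values given here, no measured pair shows this change, so the expectation is loose: no step beyond the scatter, in either direction. The estimate for a 1.3-fold lower number from compound 1 to compound 3 (0.12 log units; within the scatter) is accordingly expected to stay small. For compound 3 the estimated value is 150 umol/kg, with an expected range from 50 umol/kg to 450 umol/kg.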

Compound 3, dose for half-maximal effect: 180 umol/kg
Compound 3: the middle estimate sits 1.2-fold (0.08 log units) below what was measured, and the stated range covers the measured number.
By their numbers in this assay, from the lowest: compound 2; then compounds 3 and 1 (each within the scatter of the next).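

In this assay, the exchange of ethyl for hydrogen on an oxygen next to a carbonyl group, which turns ethoxycarbonyl into carboxy, gives a 1.1-fold lower number from compound 1 to compound 3 (0.05 log units; within the scatter) on the shared core. Going by these compounds alone, this is the first one-place comparison at this end of the molecule, and it shows that, with this chain, the ethyl group can be replaced by hydrogen without a step beyond the scatter. No independent data explain this result.
The compounds shown leave open whether carboxy and ethoxycarbonyl would also match on the chain of compound 2, since no carboxy compound with that chain appears here. They also leave open how a primary amide or a methyl ester would read in this assay at this place.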